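This account rests on a few compounds, and the source may have more. Where it says the series, first, only, none or still open, it means among the compounds named here.

Measured in an ADME assay on the whole organism (Rattus norvegicus) for metabolic stability, at a dose of 1 mg/kg by the intravenous route; on this read-out lower numbers stand for a shorter-lived compound and higher numbers for a longer-lived compound:
- compound 1 `COc1ccc(F)cc1-c1ccnc2[nH]c(C3=CCC(C(=O)O)CC3)cc12`: 2.1 h
- compound 2 `COc1ccc(F)cc1-c1ccnc2[nH]c(C3=CCC(N[C@@H](C(=O)O)C(C)C)CC3)cc12`: 0.68 h
- compound 3 `COc1ccc(F)cc1-c1c(F)cnc2[nH]c(C3=CCN([C@H]4CC[C@@H](C(=O)O)CC4)CC3)cc12`: 3 h

Compound 3, at 3 h, lies within the usual scatter of compound 1, at 2.1 h. Both sit clearly apart from compound 2, at 0.68 h, so compound 3 stands with the longer-lived pair.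

The next compound, compound 4 `COc1ccc(F)cc1-c1c(F)cnc2[nH]c(C3=CCN([C@H]4CC[C@H](C(=O)O)CC4)CC3)cc12`, has the same atoms and bonds as compound 3 and differs only in configuration as drawn: the two compounds have the same atoms and bonds and differ only in configuration as drawn: 2 of 2 stereo elements differ (all stereocentres are inverted: mirror images); a stereocentre at a saturated ring carbon is drawn s in compound 3 and r in compound 4; a stereocentre at a saturated ring carbon is drawn s in compound 3 and r in compound 4. Nothing leaves and nothing enters, so the two are mirror images.

Going by the values given here, the only measured step between two compounds that differ in one place is a 3.1-fold lower number from compound 1 to compound 2 (0.49 log units; beyond the scatter). It puts (1-carboxy-2-methylpropyl)amino in place of carboxy, so it is a change of group and offers only a rough sense of how far this read-out can move. Among the compounds with values here, no measured pair here differs in configuration alone, and the direction of such a change in this assay is unknown.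

Within the data shown here, the expectation therefore starts from compound 3 at 3 h, with no step expected beyond the scatter. The expected change is small, a 1.2-fold lower number from compound 3 to compound 4 (0.08 log units; within the scatter). For compound 4 the estimate is 2.5 h, with an expected range from 1.1 h to 5.5 h.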

Compound 4, half-life: 3.5 h
Estimate against measurement, compound 4: 1.4-fold (0.15 log units) below; measured number inside the range.
By their numbers in this assay, from the lowest: compound 2; then compounds 1, 3 and 4 (each within the scatter of the next).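

Read in this assay, this pair gives the first look at configuration on its own, and the result is a 1.2-fold higher number from compound 3 to compound 4 (0.07 log units; within the scatter). At this position, then, inverting both drawn stereocentres leaves the half-life indistinguishable from one compound to the other, whereas the earlier step, a change of group, was a 3.1-fold lower number from compound 1 to compound 2 (0.49 log units; beyond the scatter). The two steps are not a like-for-like comparison, but the new one isolates a single kind of change, since nothing leaves or enters and the pair can be read cleanly for one reason: the fact that compounds 3 and 4 differ only in the configuration as drawn

The compounds shown leave open whether configuration would matter as little if a primary amide or a methyl ester stood in place of the carboxylic acid on the saturated ring. They also leave open what would happen if only one of the two stereocentres were inverted, since here both change together and any separate contributions could not be told apart.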